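Tert-butyl for ethyl on the urea aryl ring

The compounds below may be only part of what the source reports. "The series", "measured", "known", "first", "only" and "open" are said of these compounds alone.

Compound 2 `CCc1ccc(NC(=O)N[C@@H](C)c2ccccc2)cc1` gives 95% in an ADME assay on the whole organism with Oryza sativa as the target, tested at 1 uM; a higher number here means a weaker effect of the compound at the concentration tested, a lower number a stronger effect. Among the three numbers so far, compound 2 stands second highest: compound 3 `CC(C)c1ccccc1NC(=O)N[C@@H](C)c1ccccc1` gives 96%, which lies within the usual scatter of compound 2, while compound 1 `CCc1ccc(NC(=O)N[C@H](C)c2ccccc2)cc1` gives 47%, well below. For the measured compounds named here, the only measured step between compounds that differ in a single place is a number 48 percentage points higher from compound 1 to compound 2 (beyond the scatter), and this large shift rests on (the fact that compounds 1 and 2 differ only in the configuration as drawn), a change of configuration at the saturated chain carbon rather than of any group.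

Compound 4 `C[C@H](NC(=O)Nc1ccc(C(C)(C)C)cc1)c1ccccc1` differs from compound 2 by tert-butyl in place of ethyl on an aromatic carbon. Going by the values given here, no measured step involves a change of this kind at an aromatic carbon, so the size of the step cannot be taken from any single measured pair. The two values of compound 2 and compound 3, which carry different alkyl groups on their aromatic rings yet lie within the scatter of each other, give no hint of a large effect from alkyl substitution alone. The expected step of a number 5 percentage points lower from compound 2 to compound 4 (within the scatter) is therefore none beyond the scatter. Compound 4 is estimated at 90%, with a range from 70% to 100%.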

Compound 4, a percentage reported as activity, at one concentration (the size of the read-out at that concentration, not a potency): 88%
Estimate against measurement, compound 4: 2 percentage points above, and the stated range covers the measured number.
By their numbers in this assay, from the lowest: compound 1; then compounds 4, 2 and 3 (each within the scatter of the next).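

On an aromatic carbon para to a large group, the step from ethyl to tert-butyl, which takes the substituent from 2 to 4 heavy atoms (all carbon), is a number 7 percentage points lower from compound 2 to compound 4 (within the scatter) in this assay. For the compounds shown here, this is the first step that changes a group rather than a configuration, and it shows that, with the configuration of compound 2 kept, this larger alkyl group at this position does not move the number beyond the scatter. Nothing in the data shown gives a reason for this outcome, and the one fact on record, which concerns configuration alone, does not bear on this change of group.

The compounds shown leave open whether the same exchange of ethyl for tert-butyl would also stay within the scatter in the configuration of compound 1, which is the only compound here with a number well apart from the others. They also leave open what happens at this aromatic carbon with a group other than a plain alkyl, such as an amine or a carboxylic acid, since both groups compared here are hydrocarbon chains without hydrogen-bond donors or acceptors.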